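Replacing the phenylethenyl arm of compound 1 with a dimethylaminoethyl chain

This account rests on a few compounds, and the source may have more. Where it says the series, first, only, none or still open, it means among the compounds named here.

Among the compounds with values here, compound 1 `Nc1nc(O)c2c(n1)n(C1OC(CO)[C@@H](O)[C@H]1O)c(=O)n2C/C=C/c1ccccc1` sits at the top of the three numbers so far: in a functional assay on the whole organism (B cells) with Mus musculus as the target (on this read-out lower numbers stand for smaller maximal responses and higher numbers for larger maximal responses), compound 1 gives 73%, beyond the scatter above both neighbours. Compound 2 `C=CCn1c(=O)n([C@H]2CO[C@@H](CO)C2)c2nc(N)nc(O)c21` gives 10% in this assay, and compound 3 `Cn1c(=O)n2c3c1c(=O)nc(N)n3CC1OC2[C@H](O)[C@@H]1O` gives 9%. Within the data shown here, no single-point step links any two of these three, so the effect of one isolated change has not yet been seen.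

Among the measured compounds shown here, compound 4 `CN(C)CCCn1c(=O)n(C2OC(CO)[C@@H](O)[C@H]2O)c2nc(N)nc(O)c21` is the first such single-point step from compound 1. The change is 2-(dimethylamino)ethyl in place of 2-phenylethenyl on a saturated chain carbon bound to an aromatic nitrogen. The shared core and the sugar of compound 1 are kept.

The other compounds lacking a ring on this chain, compound 2 and compound 3, lie far below compound 1, though each differs from compound 1 in more than one place. The expectation is therefore a step down beyond the scatter, a number 38 percentage points lower from compound 1 to compound 4 (beyond the scatter), while the direction is not secured by any measured single change. Compound 4 is estimated at 35%, with a range from 10% to 65%.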

Compound 4, largest response reached (reported as maximal response), in percent of the reference or control that the assay uses: 83%
For compound 4 the middle estimate is 48 percentage points below the measured one; measured number outside the range, above it.
By their numbers in this assay, from the lowest: compounds 3 and 2 (each within the scatter of the next); then compounds 1 and 4 (each within the scatter of the next).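

In this assay the swap of 2-phenylethenyl for 2-(dimethylamino)ethyl on a saturated chain carbon bound to an aromatic nitrogen gives a number 10 percentage points higher from compound 1 to compound 4 (within the scatter), the first isolated change read in this series. For this pair, the six-membered aromatic ring and the double bond of the leaving group are therefore not required to keep the maximal response within the scatter, and an arm with no ring and one nitrogen serves at this place. Nothing available explains why the two arms read alike.

On these data alone, whether a plain propyl chain without the amine, or a carboxylic acid at the chain end, would also keep this response remains open, so the part played by the dimethylamino group is not separated from that of the chain. Also open, as far as these compounds go, is whether the same swap reads alike with a different sugar on the shared core.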